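Methyl to Methoxy in a Series Tolerated by Huh-7 Cells

A few compounds are considered here, and "the series" means these few. Any claim that something is new, unique, unknown or untested is made for them only; others in the source may bear on it.

The study compares three measured compounds and one still to be measured in an ADME assay on Huh-7 cells (Homo sapiens) for cytotoxicity, read by a luciferase reporter and WST assay, with a stated time of 3 days; a lower number here means that less compound is tolerated, a higher number that more compound is tolerated. Compound 1 `COc1ccc(NC(=O)c2c(NO)cc(-c3ccccc3)oc2=O)cc1` gives > 20000 nM in this assay, which is a limit of the assay and not a number. Compound 2 `Cc1ccc(NC(=O)c2c(NO)cc(-c3ccccc3)oc2=O)cc1` likewise gives > 20000 nM in this assay, again a limit. Compound 3 `COC(=O)CNC(=O)c1c(NO)cc(-c2ccc(C)cc2)oc1=O` gives > 20000 nM in this assay, once more a limit rather than a measured number. All three values therefore sit at the limit of > 20000 nM in this assay, at which 3 of the 3 values shown sit.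

From compound 2 to compound 1 the change is methoxy in place of methyl on an aromatic carbon, and in this assay it makes a step that the two limits leave unreadable from compound 2 to compound 1, so the two limits leave its size unreadable. The difference between the core of compound 2 and the core of compound 3 is not broken down here.

Compound 4 `COC(=O)CNC(=O)c1c(NO)cc(-c2ccc(OC)cc2)oc1=O` has not yet been measured in this assay. It differs from compound 3 by methoxy in place of methyl on an aromatic carbon, the same change as that from compound 2 to compound 1, made at a place described in the same words. Among the measured compounds shown here, because the earlier pair gave a step that the two limits leave unreadable from compound 2 to compound 1 and every value so far rests at the limit of > 20000 nM in this assay, at which 3 of the 3 values shown sit, the expectation is that compound 4 will also be tolerated up to the limit of the assay. Compound 4 is therefore expected to give 25000 nM in this assay, with an estimated range from 12000 nM to 60000 nM, which means an expected step that the limit leaves unreadable from compound 3 to compound 4 from compound 3.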

Compound 4, half-maximal cytotoxic concentration: > 20000 nM
Compound 4 was reported as a limit (the forecaster's own chance of this, stated with the estimate: 85%); the middle value lies beyond the limit too.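

In this assay compound 4 gives > 20000 nM, which is a limit of the assay and not a number. Among the compounds shown here, compound 3 also stands at a limit, so no step from compound 3 to compound 4 can be read. The compounds shown leave open how methyl and methoxy compare at a readable value, and whether either lowers tolerance, for all the values rest at one limit: the limit of > 20000 nM in this assay, at which 4 of the 4 values shown sit.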